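Trifluoromethyl on the aromatic ring across two cores

The source may hold more compounds than are shown below. What is called first, only, known or untested is meant among the compounds shown, and "the series" means these compounds.

Measured so far:
compound 1, `O=C1C=COC(/C=C/c2ccccc2)C1`, 58.2 uM
compound 2, `O=C1C=COC(/C=C/c2ccc(C(F)(F)F)cc2)C1`, 58.2 uM
compound 3, `O=C1C=CCC(/C=C/c2ccccc2)N1`, > 1250 uM

In a functional assay on OVCAR-3 cells (Homo sapiens) for inhibition, read by sulforhodamine B assay, with a stated time of 48 h (on this read-out higher numbers stand for weaker inhibition of growth and lower numbers for stronger inhibition of growth), compound 1 gives 58.2 uM and compound 2 gives 58.2 uM. The step between them, no change at the digits printed from compound 1 to compound 2 (within the scatter), goes with the change (trifluoromethyl in place of hydrogen on an aromatic carbon). Compound 3 gives only a limit in this assay, namely > 1250 uM. The limit rests on (the limit of > 1250 uM in this assay, at which 1 of the 3 values shown sits). How the core of compound 3 differs from the core of compound 1 is not broken down here.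

Compound 4, `O=C1C=CCC(/C=C/c2ccccc2C(F)(F)F)N1`, has not yet been measured in this assay. It differs from compound 3 by trifluoromethyl in place of hydrogen on an aromatic carbon. Among the compounds with values here, this is the same kind of change as the one between compound 1 and compound 2, but not the same: in the measured pair the trifluoromethyl sits para to a group of 9 heavy atoms, whereas in compound 4 it sits ortho to a group of 9 heavy atoms.

Within the data shown here, the only measured trifluoromethyl step is no change at the digits printed from compound 1 to compound 2 (within the scatter), and on that basis no movement is expected from compound 3 to compound 4 either. The expected step is a number no higher from compound 3 to compound 4 (the limit leaves the size open). Compound 4 is therefore estimated at 1250 uM in this assay, with an expected span from 400 uM to 4000 uM, and most likely only a limit will again be reported.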

Compound 4, concentration for growth inhibition (reported as GI): 329 uM
The estimate for compound 4 lay 3.8-fold (0.58 log units) above the measured number, outside the stated range (below it).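

In this assay, trifluoromethyl in place of hydrogen on an aromatic carbon gives an at least 3.7-fold lower number from compound 3 to compound 4 (0.57 log units; beyond the scatter). Set beside the earlier step, this shows that the change does not carry over as a constant shift from the core of compound 1 to the core of compound 3: the same change on two cores in this assay, no change at the digits printed (within the scatter) from compound 1 to compound 2 and an at least 3.7-fold lower number (0.57 log units; beyond the scatter) from compound 3 to compound 4, at least 3.7-fold (0.57 log units) apart, beyond the scatter of two such steps. As far as these compounds go, it does not show whether the gap belongs to the core or to the place of the group, as the trifluoromethyl of compound 4 sits ortho to a group of 9 heavy atoms, a place it does not hold in compound 2, and the full size of the step also stays unknown, as the value for compound 3 is only a limit: the limit of > 1250 uM in this assay, at which 1 of the 4 values shown sits.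

Open on these compounds is how trifluoromethyl behaves when it stands at one and the same place on both cores, a comparison that would separate the contribution of the core from that of the ring place. Also open, from the compounds shown here alone, is whether other groups at that aromatic carbon, such as a chlorine, a methoxy group, an amine or a carboxylic acid, give a similar step on the core of compound 3 or on the core of compound 1.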